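Pyridin-3-yl replacing 2-chlorophenyl in a level series

The source may hold more compounds than are shown below. What is called first, only, known or untested is meant among the compounds shown, and "the series" means these compounds.

Measured so far in a functional assay on K562 cells (Homo sapiens) for cytotoxicity, read by ELISA, with a stated time of 4 days (a lower number here means a stronger inhibitor, a higher number a weaker inhibitor), are these compounds:
- compound 1 `Cc1ccc(-c2cc(-c3ccoc3)cc(-c3ccc(Cl)s3)n2)o1` at 12700 nM
- compound 2 `Cc1ccccc1-c1cc(-c2ccoc2)cc(-c2ccc(Cl)s2)n1` at 12300 nM
- compound 3 `Clc1ccc(-c2cc(-c3ccoc3)cc(-c3ccccc3Cl)n2)s1` at 15800 nM

Compound 3 at 15800 nM stands level with the other two, since a 1.2-fold higher number from compound 1 to compound 3 (0.09 log units; within the scatter) and a 1.3-fold higher number from compound 2 to compound 3 (0.11 log units; within the scatter) both lie within the scatter.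

The next structure is compound 4 `Clc1ccc(-c2cc(-c3ccoc3)cc(-c3cccnc3)n2)s1` with pyridin-3-yl in place of 2-chlorophenyl on an aromatic carbon, next to the ring nitrogen. The counted change is pyridin-3-yl in place of 2-chlorophenyl on an aromatic carbon and the 5-chlorothiophen-2-yl and furan-3-yl groups stay as they are.

Within the data shown here, the steps that bear on this are those at the same place. Besides the two above, a 1.0-fold lower number from compound 1 to compound 2 (0.01 log units; within the scatter) is also within the scatter, so 5-methylfuran-2-yl, 2-methylphenyl and 2-chlorophenyl cannot be told apart there. Among the measured compounds shown here, no measured compound carries pyridin-3-yl at this place, so the range has to stay wide and the data give no direction. No step beyond the scatter is therefore expected in this assay for this change.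

The estimated step is a 1.2-fold lower number from compound 3 to compound 4 (0.08 log units; within the scatter) and it rests on these three level compounds. For compound 4 the expected value is 13000 nM with an estimated range from 5000 nM to 35000 nM in this series.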

Compound 4, half-maximal inhibitory concentration: 18700 nM
The estimate for compound 4 lay 1.4-fold (0.16 log units) below the measured number, and the stated range covers the measured number.
By their numbers in this assay, from the lowest: compounds 2, 1, 3 and 4 (each within the scatter of the next).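

In this assay, pyridin-3-yl, a six-membered aromatic ring with 1 hetero atom and 1 hydrogen-bond acceptor, takes the place of 2-chlorophenyl, a carbon-only ring with 0 hydrogen-bond acceptors, and the number does not move beyond the scatter (a 1.2-fold higher number from compound 3 to compound 4 (0.07 log units; within the scatter)). The comparisons with the other two groups read the same way (a 1.5-fold higher number from compound 2 to compound 4 (0.18 log units; within the scatter); a 1.5-fold higher number from compound 1 to compound 4 (0.17 log units; within the scatter)), so the level set at this aromatic carbon, next to the ring nitrogen, now includes a ring with a nitrogen in it. Across these four compounds, with the 5-chlorothiophen-2-yl and furan-3-yl groups held fixed, neither the swap from a carbon-only ring to pyridin-3-yl nor the added hydrogen-bond acceptor separates pyridin-3-yl from 5-methylfuran-2-yl, 2-methylphenyl or 2-chlorophenyl.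

Still open, as far as these compounds go, is whether a primary amine, a carboxylic acid or a longer chain at this aromatic carbon would leave the number level or shift it beyond the scatter. Also open, from the compounds shown here alone, is how the number responds to changes at the 5-chlorothiophen-2-yl and furan-3-yl groups. No measurement shown here accounts for the level numbers at this position.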